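Replacing the methoxyphenyl amide with a phenylpropyl chain

The source may report more compounds than this note shows. Statements on the series, on what has been measured and on what is new or still open speak of the compounds shown alone.

Compound 1 `COc1ccc(NC(=O)COc2cc(C)nc3ccc(OC)cc23)cc1` in an ADME assay on HepG2 cells (Homo sapiens) for cytotoxicity, read by trypan blue exclusion, with a stated time of 48 h, in the presence of a further agent that is not named here (a higher number here means that more compound is tolerated, a lower number that less compound is tolerated), gives only a limit, > 142000 nM. Compound 2 `COc1ccc(NC(=O)COc2cc(C)nc3ccc(OC)cc23)c(OC)c1` likewise reaches only a limit in this assay, > 131000 nM. Compound 3 `COc1ccc2nc(C)cc(OCC(=O)Nc3ccc(OC)c(OC)c3)c2c1` also sits at a limit in this assay, > 131000 nM. The step that the two limits leave unreadable from compound 1 to compound 2 and the step that the two limits leave unreadable from compound 1 to compound 3 can therefore not be read, as the limit of > 131000 nM in this assay, at which 2 of the 3 values shown sit, and the limit of > 142000 nM in this assay, at which 1 of the 3 values shown sits, show. Compound 4 `COc1ccc2nc(C)cc(OCC(=O)NCCCc3ccccc3)c2c1` differs from compound 1 by 3-phenylpropyl in place of 4-methoxyphenyl on an amide-type nitrogen. Among the compounds with values here, no measured step touches the amide nitrogen, and the two that are known give no size or direction, so nothing in the data argues for a change beyond the scatter. Compound 4 is accordingly expected in this assay at 140000 nM, within 60000 nM to 300000 nM. The step of an at least 1.0-fold lower number from compound 1 to compound 4 (0.00 log units; that floor lies within the scatter) is expected to stay within the scatter.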

Compound 4, half-maximal cytotoxic concentration: 50700 nM
The estimate for compound 4 lay 2.8-fold (0.44 log units) above the measured number; the whole stated range lies above it.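

In this assay, the change on the amide-type nitrogen gives an at least 2.8-fold lower number from compound 1 to compound 4 (0.44 log units; beyond the scatter). This position therefore affects tolerance, which the earlier methoxy steps, none of which can be read, could not show. Compound 1 gives only a limit, so the step has a floor and no full size: the limit of > 142000 nM in this assay, at which 1 of the 4 values shown sits.

The compounds shown leave open whether the drop follows the loss of the methoxy group or the chain between nitrogen and ring. A plain phenyl or a benzyl group on the same nitrogen would separate the two.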